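The source may report more compounds than this note shows. Statements on the series, on what has been measured and on what is new or still open speak of the compounds shown alone.

Measured compounds:
Compound 1, `COc1ccc(/C=C/C2CC=CC(=O)O2)c(OC)c1`, gives 8.8 uM in a functional assay on NCI/ADR cells (Homo sapiens) for inhibition, read by sulforhodamine B assay, with a stated time of 48 h; on this read-out lower numbers stand for stronger inhibition of growth and higher numbers for weaker inhibition of growth.
Compound 2, `COc1ccc(/C=C/C2CC=CC(=O)O2)cc1OC`, gives 11.6 uM in this assay.
Compound 3, `COc1cc(/C=C/C2CC=CC(=O)O2)cc(OC)c1OC`, gives 35.1 uM in this assay.

Among these three numbers, compound 2 holds the second highest place. Its nearest neighbour is compound 1, whose number is lower by a gap that lies within the scatter, so the two cannot be told apart. The furthest is compound 3, which differs from compound 2 by a single change, methoxy in place of hydrogen on an aromatic carbon, and shows a 3.0-fold higher number from compound 2 to compound 3 (0.48 log units; beyond the scatter).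

Compound 4, `COc1cc(OC)c(OC)cc1/C=C/C1CC=CC(=O)O1`, has not yet been measured. It differs from compound 2 as follows: methoxy in place of hydrogen on an aromatic carbon. The entering methoxy group sits ortho to a group of 9 heavy atoms, meta to a methoxy group and para to a methoxy group.

Within the data shown here, only one measured step is of the same kind, the addition of a methoxy group from compound 2 to compound 3, which raised the number beyond the scatter but only modestly. On that single precedent one would expect compound 4 to show a modestly higher number than compound 2, though the new group sits at a different place, so the precedent is a loose one. The expected step is a 1.7-fold higher number from compound 2 to compound 4 (0.24 log units; within the scatter), and compound 4 is estimated at 20 uM, within a range from 7 uM to 55 uM.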

Compound 4, concentration for growth inhibition (reported as GI): 9.4 uM
For compound 4 the middle estimate is 2.1-fold (0.33 log units) above the measured one; measured number inside the range.
By their numbers in this assay, from the lowest: compounds 1, 4 and 2 (each within the scatter of the next); then compound 3.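

At this place, ortho to a group of 9 heavy atoms, meta to a methoxy group and para to a methoxy group, a methoxy group in place of hydrogen gives no change that can be read in this assay, with a 1.2-fold lower number from compound 2 to compound 4 (0.09 log units; within the scatter). The same kind of change on the other core gives a 1.1-fold higher number from compound 1 to compound 4 (0.03 log units; within the scatter), so neither step adds to the rise seen on the way to compound 3, and an added methoxy group does not raise the number in every case shown. Among these compounds the change therefore has no single size, and the gap between two of its steps is larger than the scatter allows: the same change on two cores in this assay, a 3.0-fold higher number (0.48 log units; beyond the scatter) from compound 2 to compound 3 and a 1.1-fold higher number (0.03 log units; within the scatter) from compound 1 to compound 4, 2.8-fold (0.45 log units) apart, beyond the scatter of two such steps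

The compounds shown leave open whether a hydroxyl group, an amine or a longer alkoxy chain in place of hydrogen at this position would also leave the number within the scatter. They also leave open how a compound of this series with no methoxy group on its aromatic ring would compare, so the share of the methoxy groups already present in the numbers of compound 1 and compound 2 cannot be read.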